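Hydroxy for chloro on the aryl ring of compound 2

This account rests on a few compounds, and the source may have more. Where it says the series, first, only, none or still open, it means among the compounds named here.

Measured compounds:
compound 1, `CC1(C)[C@H]2CC[C@]1(C)N(Cc1cn(-c3ccccc3F)nn1)C(=O)C2`: 300 nM
compound 2, `CC1(C)[C@H]2CC[C@]1(C)N(Cc1cn(-c3ccccc3Cl)nn1)C(=O)C2`: 40 nM
compound 3, `CC1(C)[C@H]2CC[C@]1(C)N(Cc1cn(-c3ccccc3)nn1)C(=O)C2`: 50 nM

In a functional assay on OVCAR-3 cells (Homo sapiens) for inhibition, read by MTT assay, with a stated time of 24 h (on this read-out higher numbers stand for weaker inhibition and lower numbers for stronger inhibition), compound 2 gives the lowest number of the three, but its gap to compound 3 is a 1.3-fold higher number from compound 2 to compound 3 (0.10 log units; within the scatter), which leaves the two indistinguishable; only compound 1 stands clearly apart, with a 7.5-fold lower number from compound 1 to compound 2 (0.88 log units; beyond the scatter).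

Compound 4, `CC1(C)[C@H]2CC[C@]1(C)N(Cc1cn(-c3ccccc3O)nn1)C(=O)C2`, is not yet measured. It differs from compound 2 by hydroxy in place of chloro on an aromatic carbon. Among the compounds with values here, none of the measured steps exchanges a chloro or a hydrogen for a hydroxy, so no step bears on this change directly. What the measured steps do show is that the chloro and hydrogen variants sit together (a 1.3-fold higher number from compound 2 to compound 3 (0.10 log units; within the scatter)) while the fluoro variant sits apart (a 6.0-fold lower number from compound 1 to compound 3 (0.78 log units; beyond the scatter)), so the aromatic substituent ortho to a large group does matter to this assay, in both directions of size.

Within the data shown here, with no direct precedent, compound 4 is expected to give a number somewhat higher than compound 2, a step estimated at a 2.3-fold higher number from compound 2 to compound 4 (0.35 log units; beyond the scatter). The estimate for compound 4 is 90 nM, with a range from 25 nM to 350 nM.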

Compound 4, half-maximal inhibitory concentration: 90 nM
Compound 4: middle estimate and measured number agree at the digits printed; measured number inside the range.
By their numbers in this assay, from the lowest: compounds 2, 3 and 4 (each within the scatter of the next, the first and the last beyond it); then compound 1.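

In this assay the hydroxy group, ortho to a large group, brings the first hydrogen-bond donor to this place, and the exchange for chloro gives a small but real separation (a 2.3-fold higher number from compound 2 to compound 4 (0.35 log units; beyond the scatter)). Against the hydrogen variant the same group cannot be told apart (a 1.8-fold higher number from compound 3 to compound 4 (0.26 log units; within the scatter)), so compound 4 joins compound 2 and compound 3 in one loose cluster whose two ends alone are separated beyond the scatter. Fluoro remains the only substituent standing clear of all the others, now also against hydroxy (a 3.3-fold lower number from compound 1 to compound 4 (0.52 log units; beyond the scatter)), and no measurement available here accounts for either this gap or the smaller one.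

The compounds shown leave open whether the fluoro result is peculiar to that atom or would recur with other groups at this place, and whether methoxy, an amine or a carboxylic acid in place of the hydroxy would stay within the cluster. They also leave open whether chloro, fluoro and hydroxy would rank the same way elsewhere on the aromatic ring.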